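Replacing the Ester on the Shared Core

The source may report more compounds than this note shows. Statements on the series, on what has been measured and on what is new or still open speak of the compounds shown alone.

Within the data shown here, in a functional assay for inhibition, with Homo sapiens as the target (on this read-out lower numbers stand for stronger inhibition and higher numbers for weaker inhibition), compound 1 `CCOC(=O)C(Cc1cccc(OCC(=O)O)c1)c1nc(-c2ccccc2)c(-c2ccccc2)o1` gives 120 nM, the lowest of the two numbers measured so far. Compound 2 `C[S+]([O-])C(Cc1cccc(OCC(=O)O)c1)c1nc(-c2ccccc2)c(-c2ccccc2)o1` gives 7080 nM in this assay. Among the measured compounds shown here, the only comparison available, a 59-fold higher number from compound 1 to compound 2 (1.77 log units; beyond the scatter), shows that exchanging the ethoxycarbonyl at this carbon for another group cost a great deal. Compound 3 `O=C(O)COc1cccc(CC(CCCO)c2nc(-c3ccccc3)c(-c3ccccc3)o2)c1` carries the change (3-hydroxypropyl in place of ethoxycarbonyl on a saturated chain carbon bound to an aromatic carbon and a saturated chain carbon), which again replaces the ethoxycarbonyl at that same carbon. A loss in this assay is therefore expected for compound 3, estimated as a 13-fold higher number from compound 1 to compound 3 (1.10 log units; beyond the scatter). Compound 3 is expected to give 1500 nM, within a range from 300 nM to 8000 nM.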

Compound 3, half-maximal inhibitory concentration: 1700 nM
Compound 3: the middle estimate sits 1.1-fold (0.05 log units) below what was measured, and the stated range covers the measured number.
By their numbers in this assay, from the lowest: compound 1; then compound 3; then compound 2.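

At this saturated chain carbon, a second replacement also gives a weaker result in this assay, with a 14-fold higher number from compound 1 to compound 3 (1.15 log units; beyond the scatter), so neither of the two other groups matches the ethoxycarbonyl. The size of the loss depends on the group that enters, since 3-hydroxypropyl recovers part of it, with a 4.2-fold lower number from compound 2 to compound 3 (0.62 log units; beyond the scatter). No measurement given here explains these differences. On these data alone, whether a carboxylic acid or an amide at this carbon could match the ethoxycarbonyl remains open, as does the effect of a longer chain than 3-hydroxypropyl.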